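The source may report more compounds than this note shows. Statements on the series, on what has been measured and on what is new or still open speak of the compounds shown alone.

Compound 1, `N#Cc1ccc(CN(C(=O)Nc2cc(C(F)(F)F)cc(C(F)(F)F)c2)n2cnnc2)cc1`, was tested in a functional assay on A549 cells (Homo sapiens) for cytotoxicity, read by MTT assay, with a stated time of 48 h (a lower number here means a stronger inhibitor, a higher number a weaker inhibitor), and gave 9390 nM, the lowest of the three numbers recorded so far. Compound 3, `COc1ccc(OC)c(CN(C(=O)Nc2ccc(C)cc2)n2cnnc2)c1`, gave 17400 nM, a result that sits within the usual scatter of compound 1, while compound 2, `Cc1ccc(NC(=O)N(Cc2ccccn2)n2cnnc2)cc1`, gave 21900 nM, a gap that lies beyond it. Compound 4, `COc1ccc(CN(C(=O)Nc2cc(C(F)(F)F)cc(C(F)(F)F)c2)n2cnnc2)cc1OC`, has not been measured; it differs from compound 1 by 3,4-dimethoxyphenyl in place of 4-cyanophenyl on a saturated chain carbon bound to an amide-type nitrogen. Going by the values given here, no measured pair shows this exact change, so no direction can be read from the data. The expectation for the step from compound 1 to compound 4 is therefore a 1.3-fold higher number from compound 1 to compound 4 (0.11 log units; within the scatter), essentially no change beyond the scatter. Compound 4 is estimated at 12000 nM, expected between 5000 nM and 30000 nM.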

Compound 4, half-maximal inhibitory concentration: 16200 nM
Compound 4: middle estimate off by 1.4-fold (0.13 log units), on the low side; low and high end bracket the measured number.
By their numbers in this assay, from the lowest: compounds 1, 4, 3 and 2 (each within the scatter of the next, the first and the last beyond it).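

Going by these compounds alone, on the core of compound 1, replacing 4-cyanobenzyl with 3,4-dimethoxybenzyl gives the only step read at this position in this assay: a 1.7-fold higher number from compound 1 to compound 4 (0.24 log units; within the scatter), which stays within the scatter. At this position on a saturated chain carbon bound to an amide-type nitrogen, the nitrile can therefore give way to two methoxy groups without a change this assay can resolve. No measurement here offers an explanation for this result. The compounds shown leave open whether an amine or a carboxylic acid on this phenyl ring, or a longer chain in place of the benzyl link, would move the number beyond the scatter.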